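The compounds below may be only part of what the source reports. "The series", "measured", "known", "first", "only" and "open" are said of these compounds alone.

Compound 2 `Oc1cccc(-c2cc(-c3ccc(Cl)cc3)nc(-c3cccs3)c2)c1`: 10500 nM
Compound 3 `Oc1ccc(-c2cc(-c3ccc(Cl)cc3)nc(-c3cccs3)c2)cc1`: 6450 nM
Compound 1 `Oc1cccc(-c2cc(-c3cccnc3)nc(-c3cccc(Cl)c3)c2)c1`: "not determined" (no result reported)

In a functional assay on T47D cells (Homo sapiens) for cytotoxicity, read by CCK-8 assay and cell counting, with a stated time of 2 days (a higher number here means a weaker inhibitor, a lower number a stronger inhibitor), compound 2 gives 10500 nM, the highest of the two numbers in hand. Compound 3 is its nearest neighbour: a 1.6-fold lower number from compound 2 to compound 3 (0.21 log units; within the scatter). Compound 1 carries a pyridin-3-yl group but has no number in this assay; for compound 1 the entry reads "not determined" (no result reported).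

Compound 4 `Oc1cccc(-c2cc(-c3ccc(Cl)cc3)nc(-c3cccnc3)c2)c1` differs from compound 2 in one place: pyridin-3-yl in place of thiophen-2-yl on an aromatic carbon. Among the measured compounds shown here, none of the measured steps bears on this change; the only measured step, from compound 2 to compound 3, concerns the position of the hydroxyl group and stays within the scatter. The pair of compound 1 and compound 4 cannot be compared, as compound 1 has no number. With nothing to point either way, the expected step in this assay is none beyond the scatter, so that compound 4 is estimated to give 10000 nM, with a range from 4000 nM to 25000 nM, which means an expected step of a 1.1-fold lower number from compound 2 to compound 4 (0.02 log units; within the scatter).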

Compound 4, half-maximal inhibitory concentration: 18100 nM
The estimate for compound 4 lay 1.8-fold (0.26 log units) below the measured number; low and high end bracket the measured number.
By their numbers in this assay, from the lowest: compounds 3, 2 and 4 (each within the scatter of the next, the first and the last beyond it).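

Among the compounds shown here, the position next to the ring nitrogen now has a measured step of its own, where the only earlier step concerned the hydroxyl group. In this assay, pyridin-3-yl in place of thiophen-2-yl gives a 1.7-fold higher number from compound 2 to compound 4 (0.24 log units; within the scatter), so exchanging this five-membered aromatic ring for a six-membered one, with the count of hydrogen-bond acceptors unchanged, leaves the two compounds within the scatter of each other. Nothing at hand bears on why the number falls where it does.

From the compounds shown here alone, whether a group of another kind at this position, such as an amine, a carboxylic acid or a longer alkyl chain, would move the number beyond the scatter remains open. So does whether the same exchange holds with the 4-hydroxyphenyl group of compound 3.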